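The compounds below may be only part of what the source reports. "The series", "measured", "known", "first", "only" and "open" are said of these compounds alone.

In a physicochemical assay for solubility, with a stated time of 24 h, at pH 2.2 (on this read-out higher numbers stand for higher solubility and lower numbers for lower solubility), compound 1 (`COC(=O)c1ccc2ccc(C(=O)N(C)C)c-2cc1`) gives > 64 ug/mL as its reading, which is a limit and not a number. Compound 2 (`COC(=O)c1ccc2c(C(=O)Nc3ccccc3)cn(C)c2c1`), which has a different core and carries anilino on a carbonyl carbon, gives < 1 ug/mL as its reading, also a limit. Compound 3 (`COC(=O)c1ccc2ccc(C(=O)Nc3ccccc3)c-2cc1`) keeps the core of compound 1 and has anilino in place of dimethylamino on a carbonyl carbon. Within the data shown here, no measured step isolates this change, so its size in this assay can only be estimated. Among the measured compounds shown here, the sole guide is compound 2 with its limit of < 1 ug/mL on that other core, which leaves the estimate wide. The expected change is an at least 32-fold lower number from compound 1 to compound 3 (1.50 log units; beyond the scatter) towards lower solubility, well beyond the usual scatter. For compound 3 the estimated value is 2 ug/mL with an expected range from 0.5 ug/mL to 15 ug/mL as its span.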

Compound 3, solubility: < 1 ug/mL
Compound 3 ended at the assay's limit (the forecaster's own chance of this, stated with the estimate: 40%); middle value at least 2.0-fold (0.30 log units) away from the limit.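

Among these compounds, with the core held fixed, anilino in place of dimethylamino on a carbonyl carbon now stands as the one change, and in this assay it gives an at least 64-fold lower number from compound 1 to compound 3 (1.80 log units; beyond the scatter), whereas the earlier compounds showed these two groups only on two different cores. Compound 3 sits at a limit of the assay and not at a number: the limit of < 1 ug/mL in this assay, at which 2 of the 3 values shown sit. Compound 1 also sits at a limit of the assay: the limit of > 64 ug/mL in this assay, at which 1 of the 3 values shown sits.

The compounds shown leave open whether the step goes with the aromatic ring of anilino or with the amide hydrogen; N-methylanilino, which keeps the ring without that hydrogen, and cyclohexylamino, which keeps the hydrogen without an aromatic ring, on the same carbonyl carbon would separate the two. On these data alone, how large the step truly is also stays open.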